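The source may hold more compounds than are shown below. What is called first, only, known or untested is meant among the compounds shown, and "the series" means these compounds.

Measured so far in a functional assay on HeLa cells (Homo sapiens) for antiproliferative activity, read by MTT assay, with a stated time of 48 h; a higher number here means a weaker inhibitor, a lower number a stronger inhibitor: compound 1 `COc1cc(-c2nnc(SCC(=O)c3ccc(Br)cc3)n2N)cc(OC)c1OC` gives 10400 nM. Compound 2 `COc1cc(-c2nnc(SCC(=O)c3ccc(C(F)(F)F)cc3)n2N)cc(OC)c1OC` gives 3380 nM. Compound 3 `COc1cc(-c2nnc(SCC(=O)c3ccc(F)c(F)c3)n2N)cc(OC)c1OC` gives only the assay's limit, > 100000 nM.

Compound 3 thus stands at the limit of > 100000 nM in this assay, at which 1 of the 3 values shown sits, and is the weakest of the three, both of its steps lying beyond the scatter. Compound 4 `COc1cc(-c2nnc(SCC(=O)Nc3ccccc3C)n2N)cc(OC)c1OC` differs from it by (2-methylphenyl)amino in place of 3,4-difluorophenyl on a carbonyl carbon. Going by the values given here, no measured step changes the carbonyl partner from an aryl ketone to an anilide; a 3.1-fold lower number from compound 1 to compound 2 (0.49 log units; beyond the scatter) concerns only the aryl substituent. Among the compounds with values here, the steps that bear on it are an at least 9.6-fold higher number from compound 1 to compound 3 (0.98 log units; beyond the scatter) and an at least 29-fold higher number from compound 2 to compound 3 (1.47 log units; beyond the scatter), which show that the 3,4-difluorophenyl ketone went with the largest rises seen, so leaving it is expected to lower the number, though the anilide itself is untested. Compound 4 is therefore estimated at 30000 nM, between 6000 nM and 100000 nM. The expected step is an at least 3.3-fold lower number from compound 3 to compound 4 (0.52 log units; beyond the scatter).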

Compound 4, half-maximal inhibitory concentration: > 100000 nM
Compound 4: no number, only a limit; the forecaster's own chance of this, stated with the estimate: 35%; middle value at least 3.3-fold (0.52 log units) from the limit.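

Going by these compounds alone, compound 4 gives > 100000 nM, which is a limit of the assay, and it is the first compound here with (2-methylphenyl)amino rather than an aryl group on this carbonyl carbon. That limit is now shared: the limit of > 100000 nM in this assay, at which 2 of the 4 values shown sit.

Against the two ketones with readable values, the change shows an at least 29-fold higher number from compound 2 to compound 4 (1.47 log units; beyond the scatter) and an at least 9.6-fold higher number from compound 1 to compound 4 (0.98 log units; beyond the scatter), while the step from compound 3 to compound 4 cannot be read. Going by these compounds, whether any other anilide gives a readable value stays open. So does what a morpholine amide or a carboxylic acid would give on this carbonyl carbon.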